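The source may hold more compounds than are shown below. What is called first, only, known or untested is meant among the compounds shown, and "the series" means these compounds.

Three compounds share one core and differ only in the five-membered aromatic ring attached to it. In a functional assay for activation of Alpha-1A adrenergic receptor (Homo sapiens), read by calcium flux (on this read-out lower numbers stand for an effect already at smaller amounts and higher numbers for an effect only at larger amounts of compound), compound 1 `c1ccc(-c2cnco2)c(NCC2=NCCN2)c1` gives 17.4 nM, compound 2 `c1coc(-c2ccccc2NCC2=NCCN2)c1` gives 0.468 nM, and compound 3 `Cc1nc(-c2ccccc2NCC2=NCCN2)cs1` gives 4.47 nM. Compound 3 thus holds the second highest number of the three: from compound 2 to compound 3 the change is a 9.6-fold higher number from compound 2 to compound 3 (0.98 log units; beyond the scatter), while from compound 1 to compound 3 it is a 3.9-fold lower number from compound 1 to compound 3 (0.59 log units; beyond the scatter).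

Compound 4 `Cc1cc(-c2ccccc2NCC2=NCCN2)on1` carries a different ring again: 3-methyl-1,2-oxazol-5-yl in place of 2-methyl-1,3-thiazol-4-yl on an aromatic carbon

Both measured steps into compound 3 bear on this exchange, since each also swaps one five-membered ring for another on the same carbon. Their sizes, a 9.6-fold higher number from compound 2 to compound 3 (0.98 log units; beyond the scatter) and a 3.9-fold lower number from compound 1 to compound 3 (0.59 log units; beyond the scatter), show that such swaps move this assay by modest amounts in either direction, and the two oxygen-containing rings already seen sit on opposite sides of compound 3. A modest step is therefore expected for compound 4, with no firm direction, estimated as a 1.1-fold lower number from compound 3 to compound 4 (0.05 log units; within the scatter). Compound 4 is expected to give about 4 nM in this assay, with a likely range from 1 nM to 20 nM.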

Compound 4, half-maximal effective concentration: 38.9 nM
Compound 4: the middle estimate sits 9.7-fold (0.99 log units) below what was measured, and the stated range ends below it.
By their numbers in this assay, from the lowest: compound 2; then compound 3; then compound 1; then compound 4.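

In this assay, two five-membered rings with the same counts of heavy atoms, hydrogen-bond donors and hydrogen-bond acceptors are far from interchangeable at this position: replacing 2-methyl-1,3-thiazol-4-yl with 3-methyl-1,2-oxazol-5-yl gives an 8.7-fold higher number from compound 3 to compound 4 (0.94 log units; beyond the scatter). Compound 4 now holds the highest number of the four, which widens the spread at this position to an 83-fold higher number from compound 2 to compound 4 (1.92 log units; beyond the scatter). Its step from the unmethylated oxazole ring is smaller but still beyond the usual scatter, a 2.2-fold higher number from compound 1 to compound 4 (0.35 log units; beyond the scatter), so the two rings that contain both oxygen and nitrogen give the two highest numbers among these four compounds.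

Nothing available here explains these differences between the rings. Also open, from the compounds shown here alone, is how this position would respond if an amine or a carboxylic acid took the place of the five-membered ring.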